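Methyl for 2-phenylethenyl on a carbonyl carbon

This account rests on a few compounds, and the source may have more. Where it says the series, first, only, none or still open, it means among the compounds named here.

In a functional assay on MDA-MB-231 cells (Homo sapiens) for antiproliferative activity, read by MTT assay, with a stated time of 6 days (a higher number here means a weaker inhibitor, a lower number a stronger inhibitor), compound 1 `O=C1C=C[C@@H](OCc2ccccc2)[C@@H]([C@@H](COC(=O)/C=C/c2ccccc2)OCc2ccccc2)O1` gives 4970 nM, the higher of the two numbers available. Compound 2 `COc1cccc(C(=O)OC[C@@H](OC(=O)c2cccc(OC)c2)[C@H]2OC(=O)C=C[C@H]2OC(=O)c2cccc(OC)c2)c1` gives 1580 nM, lower by more than the usual scatter. Within the data shown here, no two measured compounds differ in one place only, so no measured step bears directly on the change now under study.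

Compound 3 `CC(=O)OC[C@@H](OCc1ccccc1)[C@H]1OC(=O)C=C[C@H]1OCc1ccccc1` departs from compound 1 by a single change: methyl in place of 2-phenylethenyl on a carbonyl carbon, with methyl in place of 2-phenylethenyl on a carbonyl carbon. The same difference reads as acetoxymethyl for (((2-phenylethenyl)carbonyl)oxy)methyl. In this assay a small move towards a higher number is expected, probably not beyond the scatter, though this is weakly grounded. The estimate starts from compound 1 at 4970 nM and expects a step of a 1.2-fold higher number from compound 1 to compound 3 (0.08 log units; within the scatter). For compound 3 the estimated value is 6000 nM, with an expected range of 2000 nM to 18000 nM.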

Compound 3, half-maximal inhibitory concentration: 6420 nM
Compound 3: middle estimate off by 1.1-fold (0.03 log units), on the low side; measured number inside the range.
By their numbers in this assay, from the lowest: compound 2; then compounds 1 and 3 (each within the scatter of the next).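

In this assay the change from 2-phenylethenyl to methyl on a carbonyl carbon, read as (((2-phenylethenyl)carbonyl)oxy)methyl to acetoxymethyl, leaves the number within the scatter (a 1.3-fold higher number from compound 1 to compound 3 (0.11 log units; within the scatter)). On this core, then, the aromatic ring and the double bond that leave with 2-phenylethenyl make no measurable difference at this position, and the smaller methyl serves equally well in this pair. Nothing measured on these compounds offers an explanation for this result.

From the compounds shown here alone, whether the position is equally indifferent to other groups stays open, for example a longer alkyl chain, an amine or a carboxylic acid in place of methyl. Compound 2 differs from compound 1 and compound 3 in more than one place, so it gives no reading on this position.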